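Shrinking the carbocycle: from compound 3 to compound 4

A few compounds are considered here, and "the series" means these few. Any claim that something is new, unique, unknown or untested is made for them only; others in the source may bear on it.

For compound 1 `Oc1cc(-c2ccccc2)nn1-c1ncccc1Cl` an ADME assay on WI-38 cells (Homo sapiens) for inhibition, read by CellTiter-Glo, with a stated time of 4 days (a lower number here means a stronger inhibitor of growth, a higher number a weaker inhibitor of growth), result is > 30000 nM, which is a limit of the assay and not a number (the limit of > 30000 nM in this assay, at which 1 of the 3 values shown sits). Compound 2 `Oc1cc(C2CCCCC2)nn1-c1ccccn1` gives 9100 nM in this assay. Compound 3 `Oc1cc(C2CCCC2)nn1-c1ccccn1` gives 12700 nM in this assay; it stands highest of the two numbers shown, with compound 2 nearest, and the difference a 1.4-fold higher number from compound 2 to compound 3 (0.14 log units; within the scatter) lies within the usual scatter.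

Compound 4 `Oc1cc(C2CCC2)nn1-c1ccccn1` differs from compound 3 in one place: cyclobutyl in place of cyclopentyl on an aromatic carbon. Among the measured compounds shown here, the only measured step that bears on this change is the same shrinking of the ring by one carbon, a 1.4-fold higher number from compound 2 to compound 3 (0.14 log units; within the scatter), which was within the scatter. Another step of that kind is therefore expected to move the number little, if at all, in the direction of a somewhat higher number, with no step beyond the scatter assured.

Compound 4 is expected to give about 16000 nM in this assay, within 7000 nM to 35000 nM. This expectation amounts to a step of a 1.3-fold higher number from compound 3 to compound 4 (0.10 log units; within the scatter).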

Compound 4, concentration for 50% growth inhibition: 25000 nM
Compound 4: middle estimate off by 1.6-fold (0.19 log units), on the low side; the measured number falls inside the stated range.
By their numbers in this assay, from the lowest: compounds 2, 3 and 4 (each within the scatter of the next, the first and the last beyond it). At a limit, above all of these: compound 1.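

In this assay, the cyclohexyl, cyclopentyl and cyclobutyl groups on this aromatic carbon now give one step that stands clear of the scatter: a 2.7-fold higher number from compound 2 to compound 4 (0.44 log units; beyond the scatter). The single-carbon change remains unresolved, with a 2.0-fold higher number from compound 3 to compound 4 (0.29 log units; within the scatter) and a 1.4-fold higher number from compound 2 to compound 3 (0.14 log units; within the scatter). Across these three compounds, a weaker inhibitor of growth is therefore seen only between the two ends of the set, and that step is modest; little room remains for reading higher numbers: the limit of > 30000 nM in this assay, at which 1 of the 4 values shown sits.

On these data alone, whether the number continues on this course with cyclopropyl at the same carbon remains open. Also open, as far as these compounds go, is how an open chain such as isopropyl, or a ring bearing an amine, would read here.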